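The compounds below may be only part of what the source reports. "The series", "measured", "known", "first", "only" and "open" are said of these compounds alone.

In a functional assay on HL-60 cells (Homo sapiens) for antiproliferative activity, read by MTT assay, with a stated time of 48 h (a higher number here means a weaker inhibitor, a lower number a stronger inhibitor), compound 1 (`CCCCn1c(N)c(-c2nc3ccccc3[nH]2)c2nc(C#N)c(C#N)nc21`) gives > 50000 nM as its result, and this is a limit of the assay and not a number. Among the measured compounds shown here, compound 2 (`CN(C)CCCCn1c(N)c(C#N)c2nc(C#N)c(C#N)nc21`) gives 12900 nM as its result, the only true number so far, so it is the single firm point from which to look ahead.

The next compound is compound 3 (`CN(C)CCCCn1c(N)c(-c2nc3ccccc3o2)c2nc(C#N)c(C#N)nc21`). It keeps the 4-(dimethylamino)butyl group of compound 2 and differs from it in one place (1,3-benzoxazol-2-yl in place of cyano on an aromatic carbon). A 1,3-benzoxazol-2-yl takes the place of the cyano on an aromatic carbon of a five-membered aromatic ring, next to the ring atom that bears an amino group.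

For the measured compounds named here, no measured pair of compounds shows what this exchange does, so any forecast is a cautious judgement. The expectation is a small move a 1.6-fold lower number from compound 2 to compound 3 (0.21 log units; within the scatter) toward stronger inhibition, one that may well stay within the usual scatter of repeated measurements, and a larger move in either direction cannot be ruled out. In this assay compound 3 is estimated at 8000 nM with an expected range from 1500 nM to 40000 nM as the likely span.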

Compound 3, half-maximal inhibitory concentration: 640 nM
The estimate for compound 3 lay 13-fold (1.10 log units) above the measured number; measured number outside the range, below it.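

In this assay, replacing the cyano with a 1,3-benzoxazol-2-yl gives a 20-fold lower number from compound 2 to compound 3 (1.30 log units; beyond the scatter), a large step with the 4-(dimethylamino)butyl group held unchanged. It shows that this aromatic carbon, next to the ring atom that bears an amino group, can carry a far bigger group, made of one five-membered and one six-movement aromatic ring, and that the number falls sharply rather than rises. Nothing measured here explains why the exchange has this effect.

Among the compounds shown here, because this is the only exchange that can be read, it remains open whether both rings of the 1,3-benzoxazol-2-yl are needed, and a single phenyl ring or a furan-2-yl group at the same carbon would help to answer that. As far as these compounds go, the role of the chain also remains open, since it stays the same across this step, and a morpholine at its end or a shorter chain carrying the same dimethylamino group would test how much the result depends on it.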